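Cytotoxicity notes: benzoyl to 3-chlorobenzyl in compound 4

The source may report more compounds than this note shows. Statements on the series, on what has been measured and on what is new or still open speak of the compounds shown alone.

Compound 3 `CCC1(Cc2ccccc2)OS(=O)(=O)C=C1OC(=O)c1ccccc1` stands at a limit rather than a number in an ADME assay on HEL cells (Homo sapiens) for cytotoxicity, with a stated time of 3 days; a lower number here means that less compound is tolerated, a higher number that more compound is tolerated: compound 3 gives > 400000 nM. The same limit holds for compound 1 `CCC1(Cc2ccccc2)OS(=O)(=O)C=C1OCC(=O)OC`, which in this assay gives > 400000 nM. Compound 2 `CCC1(Cc2ccccc2)OS(=O)(=O)C=C1OCc1ccccc1` also gives only a limit in this assay, >= 50000 nM. Every step among the three is therefore unreadable: a step that the two limits leave unreadable from compound 1 to compound 2, a step that the two limits leave unreadable from compound 1 to compound 3 and a step that the two limits leave unreadable from compound 2 to compound 3; two of the values sit at the limit of > 400000 nM in this assay, at which 2 of the 3 values shown sit, and one at the limit of >= 50000 nM in this assay, at which 1 of the 3 values shown sits.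

Compound 4 `CCC1(Cc2ccccc2)OS(=O)(=O)C=C1OCc1cccc(Cl)c1` differs from compound 3 by 3-chlorobenzyl in place of benzoyl on an oxygen on an unsaturated carbon. The nearest measured step is the one between benzyl and benzoyl at the same oxygen, a step that the two limits leave unreadable from compound 2 to compound 3, and it gives no size. With all three values at limits and no readable step to lean on, compound 4 is expected to be tolerated at high concentrations as well. The step of an at least 1.3-fold lower number from compound 3 to compound 4 (0.12 log units; that floor lies within the scatter) is therefore expected to be small. The estimate for compound 4 in this assay is 300000 nM, within 50000 nM to 800000 nM, with a limit the likely outcome.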

Compound 4, minimum cytotoxic concentration: >= 20000 nM
Compound 4: a limit, no number; the forecaster's own chance of this, stated with the estimate: 70%; the middle value lies beyond the limit too.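

In this assay, going by these compounds alone, compound 4 gives >= 20000 nM as a limit and not a number, so no step from compound 1, compound 2 or compound 3 to compound 4 can be read. The compounds shown leave open what size any change at this oxygen, or the chloro in compound 4, has on the tolerated concentration.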